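The compounds below may be only part of what the source reports. "The series", "measured", "known", "first", "only" and "open" are said of these compounds alone.

Compound 1 `CC(C)C[C@H](NC(=O)OCC1CC2CCC1C2)C(=O)N[C@H](C=O)C[C@H]1CCNC1=O`: > 100000 nM
Compound 2 `CC(C)C[C@H](NC(=O)OCC1CC2CCCC(C2)C1)C(=O)N[C@@H](C[C@H]1CCNC1=O)C(O)S(=O)(=O)O`: > 100000 nM; > 100000 nM (2 entries)
Compound 3 `CC(C)C[C@H](NC(=O)OCC1CC2C=CC1C2)C(=O)N[C@@H](C[C@H]1CCNC1=O)C(O)S(=O)(=O)O`: > 100000 nM

All three numbers come from a functional assay on Huh-7 cells (Homo sapiens) for cytotoxicity; on this read-out lower numbers stand for higher toxicity in this test and higher numbers for lower toxicity in this test. For compound 3 this test returns only a limit, > 100000 nM, not a measured number. Compound 1 stands at a limit as well, > 100000 nM. Compound 2, with two entries, also ends at a limit, > 100000 nM; > 100000 nM (2 entries). Compound 3 can therefore not be placed above or below the others; every value shown sits at the edge of what the test can report, as the limit of > 100000 nM in this assay, at which 2 of the 3 values shown sit, sums up.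

Compound 4 `CC(C)C[C@H](NC(=O)OCC1CC2CCC1C2)C(=O)N[C@@H](C[C@H]1CCNC1=O)C(O)S(=O)(=O)O` has not been measured yet. It differs from compound 3 in one place: a group of 7 heavy atoms (7 carbon; 2 five-membered non-aromatic rings of carbon only) in place of a group of 7 heavy atoms (7 carbon; 2 five-membered non-aromatic rings of carbon only), on a saturated chain carbon bound to an oxygen next to a carbonyl group. Within the data shown here, no pair of measured compounds shows what such a swap does, so the expectation rests on the neighbours. Since compound 1 carries the same entering group and gives only the limit > 100000 nM, no shift beyond the usual scatter is expected, and the step from compound 3 is estimated as a step that the limit leaves unreadable from compound 3 to compound 4. Compound 4 is expected to come out at 150000 nM, within a range of 100000 nM to 500000 nM, most probably again reported as a limit rather than a number.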

Compound 4, half-maximal cytotoxic concentration: > 100000 nM
Compound 4 ended at the assay's limit (the forecaster's own chance of this, stated with the estimate: 85%); the middle value does not contradict the limit.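

The steps from compound 3 to compound 4 and from compound 1 to compound 4 cannot be read, because each pair ends at the same limit rather than at a number: the limit of > 100000 nM in this assay, at which 3 of the 4 values shown sit.

Whether the groups that differ among these compounds change toxicity at all in this assay stays open.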